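Swapping a fluorophenyl ketone for isopropoxy on the ring

A few compounds are considered here, and "the series" means these few. Any claim that something is new, unique, unknown or untested is made for them only; others in the source may bear on it.

Three compounds share one core. Compound 1 `CCCCNc1nc(C(F)(F)F)ccc1CNC(=O)C(C)c1ccc(NS(C)(=O)=O)c(F)c1` gives 9.1 nM in a functional assay on CHO-K1 cells for antagonist activity at transient receptor potential cation channel subfamily V member 1 (Homo sapiens), read by FLIPR; a lower number here means a stronger inhibitor, a higher number a weaker inhibitor. Compound 2 `CC(C(=O)NCc1ccc(C(F)(F)F)nc1NCc1ccc(Cl)cc1)c1ccc(NS(C)(=O)=O)c(F)c1` gives 65.7 nM, and compound 3 `CC(C(=O)NCc1ccc(C(F)(F)F)nc1N1CCC(C(=O)c2ccc(F)cc2)CC1)c1ccc(NS(C)(=O)=O)c(F)c1` gives 3.9 nM. Compound 3 stands lowest of the three numbers, with compound 1 nearest and compound 2 furthest. Going by the values given here, the one single-point step among them, a 7.2-fold higher number from compound 1 to compound 2 (0.86 log units; beyond the scatter), shows that an aromatic ring entering in place of a short alkyl on the chain bound to the ring nitrogen is a modest loss.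

Compound 4 `CC(C)OC1CCN(c2nc(C(F)(F)F)ccc2CNC(=O)C(C)c2ccc(NS(C)(=O)=O)c(F)c2)CC1` differs from compound 3 by isopropoxy in place of (4-fluorophenyl)carbonyl on a saturated ring carbon, on the six-membered non-aromatic ring with one nitrogen. Here an aromatic group leaves and a small alkoxy enters, the reverse sense of the step from compound 1 to compound 2, though at a different place. Among the compounds with values here, no measured step tests this ring carbon directly, so the expectation is loose. Compound 4 is expected to give about 8 nM, within 2.5 nM to 25 nM, a step of a 2.1-fold higher number from compound 3 to compound 4 (0.31 log units; beyond the scatter) that may not exceed the scatter.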

Compound 4, inhibition constant: 3 nM
Estimate against measurement, compound 4: 2.7-fold (0.43 log units) above, within the range that was stated.
By their numbers in this assay, from the lowest: compounds 4 and 3 (each within the scatter of the next); then compound 1; then compound 2.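

In this assay, isopropoxy can stand in place of (4-fluorophenyl)carbonyl on this saturated ring carbon with no change beyond the scatter, a 1.3-fold lower number from compound 3 to compound 4 (0.11 log units; within the scatter), so the six-membered aromatic ring of the leaving group is not needed to keep the number this low. The 4-isopropoxypiperidin-1-yl group also compares well with the amino groups on the aromatic carbon, with a modest step from butylamino, a 3.0-fold lower number from compound 1 to compound 4 (0.48 log units; beyond the scatter), and a large one from (4-chlorobenzyl)amino, a 22-fold lower number from compound 2 to compound 4 (1.34 log units; beyond the scatter). Nothing measured here accounts for these steps.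

The compounds shown leave open how this ring carbon would respond to a hydroxyl, a carboxylic acid or a longer chain such as butoxy. They also leave open whether a primary amine there would keep the number equally low.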